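A few compounds are considered here, and "the series" means these few. Any claim that something is new, unique, unknown or untested is made for them only; others in the source may bear on it.

Measured so far in a functional assay on MGC-803 cells (Homo sapiens) for inhibition, read by MTT assay, with a stated time of 48 h; on this read-out higher numbers stand for weaker inhibition and lower numbers for stronger inhibition:
- compound 1 `COc1ccc(CNc2cc(OC)c(OC)c(OC)c2)cc1[N+](=O)[O-]` gives 19400 nM
- compound 2 `COc1ccc(CN(C(C)=O)c2cc(OC)c(OC)c(OC)c2)cc1O` gives 79 nM
- compound 3 `C/C=C/C(=O)N(Cc1ccc(OC)c(N)c1)c1cc(OC)c(OC)c(OC)c1` gives 150 nM

Compound 2 holds the lowest number of the three in this assay. Its gap to compound 3 is within the usual scatter, so these two cannot be put in order on the values shown. Its gap to compound 1 is far beyond the scatter.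

Compound 4 `C=C(C)C(=O)N(Cc1ccc(OC)c(O)c1)c1cc(OC)c(OC)c(OC)c1` is compound 2 with a single change: 1-methylethenyl in place of methyl on a carbonyl carbon. Cut one bond further out, the acetyl becomes a (1-methylethenyl)carbonyl; everything else in the structure stays as in compound 2. Within the data shown here, no measured pair isolates this change, so its size is not known from the series. The closest guide is compound 3, which carries a different unsaturated acyl group on the amide-type nitrogen and differs from compound 2 elsewhere as well, yet gives a value in this assay within the scatter of compound 2. On that basis the step from compound 2 to compound 4 is expected to be small, with no clear direction and most likely none beyond the scatter; the step of a 1.4-fold higher number from compound 2 to compound 4 (0.14 log units; within the scatter) is the estimate. Compound 4 is therefore expected to give about 110 nM in this assay, within a range of 40 nM to 350 nM.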

Compound 4, half-maximal inhibitory concentration: 390 nM
Compound 4: the middle estimate sits 3.5-fold (0.55 log units) below what was measured, and the stated range ends below it.
By their numbers in this assay, from the lowest: compounds 2 and 3 (each within the scatter of the next); then compound 4; then compound 1.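

In this assay, among these compounds, the change from acetyl to (1-methylethenyl)carbonyl on the amide-type nitrogen, with everything else in the structure held, comes with a 4.9-fold higher number from compound 2 to compound 4 (0.69 log units; beyond the scatter) and is the first step to isolate this position. The position is therefore not indifferent to the group on the carbonyl carbon: 1-methylethenyl, with 3 heavy atoms and a double bond outside aromatic rings, gives a higher number than methyl, with 1 heavy atom, and the step is modest rather than large. Nothing available here accounts for this step.

Among the compounds shown here, the single step cannot separate the added carbon atoms from the double bond, and an isopropyl group on the same carbonyl carbon would pull these two apart, while a longer chain such as propyl would show whether the number keeps rising as the group grows. Also open, as far as these compounds go, is how far this position tolerates a change of kind, for example an amine on the carbonyl carbon in place of methyl, or a carboxylic acid at the end of the acyl chain.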